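Cyclohexyl in place of octyl on the shared core

The source may report more compounds than this note shows. Statements on the series, on what has been measured and on what is new or still open speak of the compounds shown alone.

Three measured compounds share one core and differ only in the group on the five-membered aromatic ring. Compound 1 `CC1(c2nc(-c3ccc(CNC(=O)[C@H]4NCC[C@@H]4O)cc3)no2)CCCCC1` gives 210 nM in an assay on isolated protein for inhibition of sphingosine kinase 1 (Homo sapiens); a lower number here means a stronger inhibitor, a higher number a weaker inhibitor. Compound 2 `O=C(NCc1ccc(-c2noc(CCC3CC3)n2)cc1)[C@H]1NCC[C@@H]1O` gives 5000 nM in this assay, and compound 3 `CCCCCCCCc1nc(-c2ccc(CNC(=O)[C@H]3NCC[C@@H]3O)cc2)no1` gives 86 nM in this assay, the lowest of the three numbers. The steps among them: a 24-fold higher number from compound 1 to compound 2 (1.38 log units; beyond the scatter); a 2.4-fold lower number from compound 1 to compound 3 (0.39 log units; beyond the scatter); a 58-fold lower number from compound 2 to compound 3 (1.76 log units; beyond the scatter).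

Compound 4 `O=C(NCc1ccc(-c2noc(C3CCCCC3)n2)cc1)[C@H]1NCC[C@@H]1O` is not yet measured. Its change from compound 3: cyclohexyl in place of octyl on an aromatic carbon. The step that bears most directly is a 2.4-fold lower number from compound 1 to compound 3 (0.39 log units; beyond the scatter), as 1-methylcyclohexyl and cyclohexyl share the six-membered ring and differ only by a methyl. The large step of a 58-fold lower number from compound 2 to compound 3 (1.76 log units; beyond the scatter) and the large step of a 24-fold higher number from compound 1 to compound 2 (1.38 log units; beyond the scatter) both set 2-cyclopropylethyl far apart from the other groups, and cyclohexyl is structurally closer to 1-methylcyclohexyl than to 2-cyclopropylethyl. A modest rise in this assay toward the number of compound 1 is therefore expected, not a large one.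

Compound 4 is expected to give about 300 nM in this assay, with a range of 120 nM to 800 nM. This corresponds to an expected step of a 3.5-fold higher number from compound 3 to compound 4 (0.54 log units; beyond the scatter).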

Compound 4, half-maximal inhibitory concentration: 380 nM
The estimate for compound 4 lay 1.3-fold (0.10 log units) below the measured number; the range from low to high includes it.
By their numbers in this assay, from the lowest: compound 3; then compounds 1 and 4 (each within the scatter of the next); then compound 2.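

In this assay, the step of a 1.8-fold higher number from compound 1 to compound 4 (0.26 log units; within the scatter) shows that on this saturated ring carbon, hydrogen in place of methyl leaves the number unchanged within the scatter, so compounds 1 and 4 read as one six-membered ring pair. Against that pair, the step of a 4.4-fold higher number from compound 3 to compound 4 (0.65 log units; beyond the scatter) gives the first direct comparison of octyl with cyclohexyl on this aromatic carbon, and it agrees with the step from compound 1 to compound 3 in leaving octyl with the lower number. The step of a 13-fold lower number from compound 2 to compound 4 (1.12 log units; beyond the scatter) shows that the high number of compound 2 belongs to 2-cyclopropylethyl in comparison with cyclohexyl as well as with the other two groups, while no measurement at hand accounts for any of these differences.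

The compounds shown do not separate the effect of chain length from that of the ring, since octyl and cyclohexyl differ in both, and a decyl chain or a hexyl chain on the same carbon would bear on that. Also open, going by these compounds, is whether a terminal amine or carboxylic acid on the octyl chain would keep the number of compound 3.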